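Methyl for Dibromomethyl: Expected Shift in Cytotoxicity

The source may hold more compounds than are shown below. What is called first, only, known or untested is meant among the compounds shown, and "the series" means these compounds.

compound 1 `CCC[C@@H](OC(C)=O)C1=C(Br)[C@@](C)(OC)OC1=O` 10.7 ug/mL
compound 2 `CCC[C@@H](OC(C)=O)C1=C(Br)[C@@](OC)(C(Br)Br)OC1=O` 3.9 ug/mL

In a functional assay on KB cells (Homo sapiens) for cytotoxicity (on this read-out lower numbers stand for an effect already at smaller amounts and higher numbers for an effect only at larger amounts of compound), compound 2 gives the lower of the two measured numbers; compound 1 gives 10.7 ug/mL, a gap beyond the usual scatter. Compound 3 `CCC[C@@H](OC(C)=O)C1=C(Br)[C@](C)(OC)OC1=O` has not yet been measured. It differs from compound 2 by methyl in place of dibromomethyl on a saturated ring carbon. Compound 1 also carries methyl rather than dibromomethyl and gives 10.7 ug/mL. On that basis the step of a 2.6-fold higher number from compound 2 to compound 3 (0.41 log units; beyond the scatter) is expected to be an increase beyond the scatter. Compound 3 is therefore estimated at 10 ug/mL, within a range from 5 ug/mL to 20 ug/mL.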

Compound 3, concentration for half-maximal effect: 5.6 ug/mL
Estimate against measurement, compound 3: 1.8-fold (0.25 log units) above; the range from low to high includes it.
By their numbers in this assay, from the lowest: compounds 2, 3 and 1 (each within the scatter of the next, the first and the last beyond it).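

In this assay, methyl in place of dibromomethyl on this saturated ring carbon gives a 1.4-fold higher number from compound 2 to compound 3 (0.16 log units; within the scatter), so this exchange of groups produces no difference beyond the scatter. Changing the drawn configuration at the same carbon gives a 1.9-fold lower number from compound 1 to compound 3 (0.28 log units; within the scatter), which is also within the scatter. This second comparison isolates the stereocentre alone, resting on one point: the fact that compounds 1 and 3 differ only in the configuration as drawn

The compounds shown leave open how an amine, a carboxylic acid or a longer chain on this ring carbon would read out in this assay. They also leave open whether configuration at this carbon matters with any group other than methyl.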